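Nitrooxy to Trifluoromethyl on the Sulfonyl Aryl, Two Cores

The compounds below may be only part of what the source reports. "The series", "measured", "known", "first", "only" and "open" are said of these compounds alone.

Measured so far in a functional assay on SMMC-7721 cells (Homo sapiens) for cytotoxicity, read by MTT assay, with a stated time of 24 h; a higher number here means a weaker inhibitor, a lower number a stronger inhibitor:
compound 1 `O=C1/C(=C/c2cccc(F)c2)CN(S(=O)(=O)c2ccc(O[N+](=O)[O-])cc2)C/C1=C\c1cccc(F)c1`: 15300 nM
compound 2 `O=C1/C(=C/c2cccc(F)c2)CN(S(=O)(=O)c2ccc(C(F)(F)F)cc2)C/C1=C\c1cccc(F)c1`: 4200 nM
compound 3 `O=C1/C(=C/c2ccc(F)cc2)CN(S(=O)(=O)c2ccc(O[N+](=O)[O-])cc2)C/C1=C\c1ccc(F)cc1`: 5000 nM

Compound 1 and compound 2 share one core, compound 3 and compound 4 another. The difference between the two cores is not broken down here. Within the first pair the change is trifluoromethyl in place of nitrooxy on an aromatic carbon, and it gave a 3.6-fold lower number from compound 1 to compound 2 (0.56 log units; beyond the scatter). Compound 2 and compound 3 sit within the usual scatter of each other, so nothing is said of their order.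

Compound 4 `O=C1/C(=C/c2ccc(F)cc2)CN(S(=O)(=O)c2ccc(C(F)(F)F)cc2)C/C1=C\c1ccc(F)cc1` has not yet been measured. It differs from compound 3 by trifluoromethyl in place of nitrooxy on an aromatic carbon, the same change as before, at a place described in the same words. Only one earlier instance of this change exists among the compounds shown, so the expectation rests on a single step, a 3.6-fold lower number from compound 1 to compound 2 (0.56 log units; beyond the scatter), carried over to the second core. Compound 4 is therefore expected to give about 1500 nM in this assay. That would mean an estimated 3.3-fold lower number from compound 3 to compound 4 (0.52 log units; beyond the scatter). Compound 4 is expected to fall between 600 nM and 4000 nM.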

Compound 4, half-maximal inhibitory concentration: 4400 nM
The estimate for compound 4 lay 2.9-fold (0.47 log units) below the measured number; the whole stated range lies below it.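

In this assay, trifluoromethyl in place of nitrooxy on the second core gave a 1.1-fold lower number from compound 3 to compound 4 (0.06 log units; within the scatter), so the clear step seen on the first core did not reappear. The size of this step therefore did not carry from one core to the other, and the two instances disagree: the same change on two cores in this assay, a 3.6-fold lower number (0.56 log units; beyond the scatter) from compound 1 to compound 2 and a 1.1-fold lower number (0.06 log units; within the scatter) from compound 3 to compound 4, 3.2-fold (0.51 log units) apart, beyond the scatter of two such steps This shows that, across these two pairs, the outcome of the change depended on the core it was made on, but it does not show which feature of the cores is responsible, and two pairs give no rule for how the change would behave on any further core.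

The compounds shown leave open whether other groups at the same place on the sulfonyl aryl, such as an amine, a carboxylic acid or a methoxy group, would also give steps that differ between the two cores. They also leave open whether the same disagreement would appear on a core with chlorine in place of fluorine on its two outer aryl rings.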